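A few compounds are considered here, and "the series" means these few. Any claim that something is new, unique, unknown or untested is made for them only; others in the source may bear on it.

Three amides sharing one core have been tested in a functional assay on HCT-116 cells (Homo sapiens) for antiproliferative activity, read by MTT assay, with a stated time of 72 h; on this read-out lower numbers stand for stronger inhibition and higher numbers for weaker inhibition. Compound 1 `O=C(CCc1cccc2c1B(O)OC2)Nc1nccs1` reaches only a limit of the assay, > 100000 nM. Compound 2 `O=C(CCc1cccc2c1B(O)OC2)Nc1ccc(I)cc1` gives 50000 nM, and compound 3 `O=C(CCc1cccc2c1B(O)OC2)Nc1cccc(I)c1` gives 2300 nM, the lowest number of the three. Compound 3 stands clear of the others, with a 22-fold lower number from compound 2 to compound 3 (1.34 log units; beyond the scatter) and an at least 43-fold lower number from compound 1 to compound 3 (1.63 log units; beyond the scatter). Compound 4 `COc1ccc(-c2cccc(NC(=O)CCc3cccc4c3B(O)OC4)c2)cc1` keeps the 3-substituted phenyl amide of compound 3 but carries a new group: 4-methoxyphenyl in place of iodo on an aromatic carbon. The 4-methoxyphenyl group thus sits on the aromatic carbon that held iodo, meta to a large group. Among the measured compounds shown here, no measured step makes this replacement. The nearest guide is a 22-fold lower number from compound 2 to compound 3 (1.34 log units; beyond the scatter), which shows that a change confined to the aryl group can be large, though it gives no direction here. A step beyond the scatter is therefore not expected in either direction, but the range is kept wide. For compound 4 the expected step is a 1.3-fold higher number from compound 3 to compound 4 (0.12 log units; within the scatter). In this assay compound 4 is estimated at 3000 nM, with an expected range from 500 nM to 20000 nM.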

Compound 4, half-maximal inhibitory concentration: 160 nM
For compound 4 the middle estimate is 19-fold (1.27 log units) above the measured one; measured number below the stated range.
By their numbers in this assay, from the lowest: compound 4; then compound 3; then compound 2. At a limit, above all of these: compound 1.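

In this assay, the aromatic carbon that held iodo accepts a much larger group with a gain rather than a loss: a 14-fold lower number from compound 3 to compound 4 (1.16 log units; beyond the scatter). Among the compounds shown here, the earlier compounds varied only the group on the amide nitrogen, and none carried more than iodo on its aryl group, so this is the first evidence that 4-methoxyphenyl, with 8 heavy atoms and one six-membered aromatic ring, is tolerated here and goes with a lower number. Nothing given here accounts for this gain.

The compounds shown leave open whether the gain comes from the added aromatic ring or from its methoxy group; a plain phenyl, or an amine or a carboxylic acid in place of that methoxy, would separate the two. Also open, on these data alone, is whether 4-methoxyphenyl would produce a similar step in place of the iodo of compound 2.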